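Swapping Methyl for Ethoxy on the Shared Core

This account rests on a few compounds, and the source may have more. Where it says the series, first, only, none or still open, it means among the compounds named here.

Compound 2 `Cc1cccc2cc(C(=O)O)cnc12` carries a methyl on the shared core, where compound 1 `O=C(O)c1cnc2c(Cl)cccc2c1` carries a chloro. In a functional assay on the whole organism (strain Sprague-Dawley) for inhibition, with Rattus norvegicus as the target (a higher number here means that more compound is needed for the effect, a lower number that less compound is needed), compound 1 gives 150 mg/kg. In this assay compound 2 gives a limit of the assay rather than a number, > 25 mg/kg. Where compound 2 stands is therefore known only as that limit. For the measured compounds named here, the one measured step, a step that the limit leaves unreadable from compound 1 to compound 2, is left unreadable by the limit (the limit of > 25 mg/kg in this assay, at which 1 of the 2 values shown sits), so its size and direction are unknown. Compound 3 `CCOc1cccc2cc(C(=O)O)cnc12` differs from compound 2 in one place: ethoxy in place of methyl on an aromatic carbon. No measured step involves an ethoxy, so nothing among these compounds sets the direction or size of this change, and the expected step that the limit leaves unreadable from compound 2 to compound 3 is accordingly no more than a cautious guess. Compound 3 is expected to give about 100 mg/kg, between 25 mg/kg and 400 mg/kg, with a real chance that again only a limit is reported.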

Compound 3, minimum effective dose: > 50 mg/kg
Compound 3 was reported as a limit; the forecaster's own chance of this, stated with the estimate: 50%; the middle value is on the limit's open side.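

No new step can be read among compound 1, compound 2 and compound 3, since compound 2 and compound 3 each give only a limit in this assay. Still open, on these data alone, is whether chloro, methyl or ethoxy on the shared core needs less compound for the effect, and by how much.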